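Moving the Methoxy Group on a Biaryl Amide

A few compounds are considered here, and "the series" means these few. Any claim that something is new, unique, unknown or untested is made for them only; others in the source may bear on it.

Compound 1 `COC(=O)/C=C/c1cccc(N(Cc2ccc(-c3ccc(OC)cc3)cc2)C(=O)C2CCCCC2)c1` gives 89 nM in an assay on isolated protein with Bile acid receptor (Homo sapiens) as the target; a lower number here means that less compound is needed, a higher number that more compound is needed for the effect.
Compound 2 `COC(=O)/C=C/c1cccc(N(Cc2ccc(-c3ccc(OC)cc3)cc2)C(=O)C(C)C)c1` gives 97 nM in this assay.
Compound 3 `CC(C)(C)OC(=O)/C=C/c1ccc(CN(C(=O)C2CCCCC2)c2cccc(/C=C/C(=O)OC(C)(C)C)c2)cc1` gives only a limit of the assay, > 1000 nM, in this assay.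
Compound 4 `COC(=O)/C=C/c1cccc(N(Cc2ccc(-c3cccc(OC)c3)cc2)C(=O)C(C)C)c1` has not yet been measured in this assay.

Of the two numbers, compound 2 gives the higher one, with compound 1 nearest to it: a 1.1-fold higher number from compound 1 to compound 2 (0.04 log units; within the scatter). Compound 3 sits at the limit of > 1000 nM in this assay, at which 1 of the 3 values shown sits, and contributes no number. Compound 4 differs from compound 2 in a single place: 3-methoxyphenyl in place of 4-methoxyphenyl on an aromatic carbon. For the measured compounds named here, the one measured step exchanged the acyl group and leaves the methoxyphenyl untouched, so no measured step bears directly on this change. No step beyond the scatter is therefore expected, a 1.5-fold higher number from compound 2 to compound 4 (0.19 log units; within the scatter). Compound 4 is expected to give 150 nM in this assay, with a plausible range from 50 nM to 500 nM.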

Compound 4, half-maximal effective concentration: 72 nM
The estimate for compound 4 lay 2.1-fold (0.32 log units) above the measured number; low and high end bracket the measured number.
By their numbers in this assay, from the lowest: compounds 4, 1 and 2 (each within the scatter of the next). At a limit, above all of these: compound 3.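

In this assay, the exchange of 4-methoxyphenyl for 3-methoxyphenyl is the first change shown on this ring, and it stays within the scatter: a 1.3-fold lower number from compound 2 to compound 4 (0.13 log units; within the scatter). With the isopropyl amide, then, the methoxy group can occupy either of these two places without a step beyond the scatter. Nothing shown gives a reason for this outcome.

From the compounds shown here alone, it remains open whether the same holds with the cyclohexyl amide of compound 1. Also open, going by these compounds, is what 2-methoxyphenyl, or an ethoxy, hydroxyl or amine group on this ring, would give.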